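This account rests on a few compounds, and the source may have more. Where it says the series, first, only, none or still open, it means among the compounds named here.

Measured compounds:
compound 1 `CC1(C)CC12NC(=O)N(NC(=O)c1ccc(Cl)cc1)C2=O` — 100 mg/kg
compound 2 `CC1(C)CC12NC(=O)N(NC(=O)c1ccc(F)cc1)C2=O` — 100 mg/kg

In a functional assay on the whole organism (Hindlimb) for inhibition, with Mus musculus as the target, with a stated time of 0.5 h (a higher number here means that more compound is needed for the effect, a lower number that less compound is needed), compound 1 gives 100 mg/kg. In this assay compound 2 gives 100 mg/kg, level with compound 1; the step of no change at the digits printed from compound 1 to compound 2 (within the scatter) shows no change within the scatter, so exchanging one halogen for the other on the aromatic carbon left the minimum effective dose where it was.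

Compound 3 `CC1(C)CC12NC(=O)N(NC(=O)c1ccc(C(F)(F)F)cc1)C2=O` is not yet measured. It differs from compound 2 by trifluoromethyl in place of fluoro on an aromatic carbon. Among the compounds with values here, the only measured step, no change at the digits printed from compound 1 to compound 2 (within the scatter), bears on it indirectly: it shows that the group on that aromatic carbon could be varied without a change beyond the scatter. Within the data shown here, no measured step involves a trifluoromethyl group, so the expectation rests on that single halogen exchange alone.

For compound 3 the minimum effective dose in this assay is therefore expected to stay close to that of compound 2, with an expected step of no change at the digits printed from compound 2 to compound 3 (within the scatter) and an estimate of 100 mg/kg (range 30 mg/kg to 300 mg/kg).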

Compound 3, minimum effective dose: 30 mg/kg
Estimate against measurement, compound 3: 3.3-fold (0.52 log units) above; measured number inside the range.
By their numbers in this assay, from the lowest: compound 3; then compounds 1 and 2 (each within the scatter of the next).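

At the aromatic carbon para to a large group, the substituent does register in this assay: trifluoromethyl in place of fluoro gives a 3.3-fold lower number from compound 2 to compound 3 (0.52 log units; beyond the scatter), and trifluoromethyl in place of chloro gives a 3.3-fold lower number from compound 1 to compound 3 (0.52 log units; beyond the scatter). The position is therefore not indifferent to what it carries, even though the exchange of one halogen for the other gave no change beyond the scatter. No measurement shown bears on why the number falls with trifluoromethyl.

The compounds shown leave open whether the lower minimum effective dose belongs to trifluoromethyl alone or extends to other groups on this carbon, such as a nitrile, a methoxy group or an amine. They also leave open whether trifluoromethyl on another carbon of the aromatic ring would give the same reading.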